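Chloro in Place of Methylsulfonyl: Expected Return of Potency

The source may report more compounds than this note shows. Statements on the series, on what has been measured and on what is new or still open speak of the compounds shown alone.

Of the compounds shown here, three with a shared core have been measured in a functional assay on MCF7 cells (Homo sapiens) for cytotoxicity, read by CCK-8 assay, with a stated time of 24 h; a higher number here means a weaker inhibitor, a lower number a stronger inhibitor. Compound 1 `C/C(=C\c1cc(-c2ccccc2)cs1)C(N)=O` gives 2680 nM in this assay, and compound 2 `C/C(=C\c1cc(-c2ccc(F)cc2)cs1)C(N)=O` gives 1440 nM. For compound 3 `C/C(=C\c1cc(-c2ccc(S(C)(=O)=O)cc2)cs1)C(N)=O` the assay reports only a limit, > 50000 nM, and no number. Compound 3 therefore stands at the weak end of the three, at the limit of > 50000 nM in this assay, at which 1 of the 3 values shown sits.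

Two measured steps lead to compound 3: an at least 18-fold higher number from compound 1 to compound 3 (1.27 log units; beyond the scatter) and an at least 34-fold higher number from compound 2 to compound 3 (1.54 log units; beyond the scatter). Both show that methylsulfonyl on this aromatic carbon is tied to a large loss, whereas a 1.9-fold lower number from compound 1 to compound 2 (0.27 log units; within the scatter) shows that hydrogen and fluoro there give values within the scatter of each other.

Compound 4 `C/C(=C\c1cc(-c2ccc(Cl)cc2)cs1)C(N)=O` differs from compound 3 by chloro in place of methylsulfonyl on an aromatic carbon. Since a chloro group, like the hydrogen of compound 1 and the fluoro of compound 2, removes the methylsulfonyl, the number for compound 4 is expected to fall back toward the values of compounds 1 and 2, a step of an at least 33-fold lower number from compound 3 to compound 4 (1.52 log units; beyond the scatter). Compound 4 is thus estimated at 1500 nM, with a range from 500 nM to 6000 nM.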

Compound 4, half-maximal inhibitory concentration: 17100 nM
The estimate for compound 4 lay 11-fold (1.06 log units) below the measured number; the measured number lies above the stated range.
By their numbers in this assay, from the lowest: compounds 2 and 1 (each within the scatter of the next); then compound 4. At a limit, above all of these: compound 3.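

In this assay, chloro in place of methylsulfonyl brings back some activity, with an at least 2.9-fold lower number from compound 3 to compound 4 (0.46 log units; beyond the scatter), but this step gives only a bound, as compound 3 stands at a limit: the limit of > 50000 nM in this assay, at which 1 of the 4 values shown sits. Hydrogen and fluoro had stayed within the scatter of each other, yet chloro at the same place is set apart from both, with a 12-fold higher number from compound 2 to compound 4 (1.07 log units; beyond the scatter) and a 6.4-fold higher number from compound 1 to compound 4 (0.80 log units; beyond the scatter). The position therefore does not divide simply into methylsulfonyl and everything else, since it also separates chloro from hydrogen and fluoro.

Going by these compounds, what bromo, methyl, methoxy or an amine would give at this place remains open. The limit for compound 3 also leaves open how much of the loss chloro recovers.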